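The source may report more compounds than this note shows. Statements on the series, on what has been measured and on what is new or still open speak of the compounds shown alone.

Compound 1 `OCCCCC#Cc1ccccc1C#Cc1cccs1` gives 19000 nM in a functional assay on SF-295 cells (Homo sapiens) for cytotoxicity; on this read-out higher numbers stand for weaker inhibition of growth and lower numbers for stronger inhibition of growth.
Compound 2 `OCCCCC#Cc1ccccc1C#Cc1ccc(O)cc1` gives 16200 nM in this assay.

Compound 2 stands lowest of the two numbers, with compound 1 nearest at a 1.2-fold lower number from compound 1 to compound 2 (0.07 log units; within the scatter). Compound 3 `N#Cc1ccc(C#Cc2ccccc2C#CCCCCO)cc1` carries cyano in place of hydroxy on an aromatic carbon. Within the data shown here, the only measured step, the exchange of the aryl group on the triple-bonded carbon, was a 1.2-fold lower number from compound 1 to compound 2 (0.07 log units; within the scatter); it bears only loosely on a change of the group on that ring and gives no hint of a large effect. Compound 3 is therefore expected to show no step beyond the scatter, a 1.1-fold lower number from compound 2 to compound 3 (0.03 log units; within the scatter). Compound 3 is estimated at 15000 nM, between 6000 nM and 40000 nM.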

Compound 3, concentration for 50% growth inhibition: 21500 nM
Estimate against measurement, compound 3: 1.4-fold (0.16 log units) below; the range from low to high includes it.
By their numbers in this assay, from the lowest: compounds 2, 1 and 3 (each within the scatter of the next).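

With cyano in place of hydroxy on the aromatic carbon para to a large group, the result is a 1.3-fold higher number from compound 2 to compound 3 (0.12 log units; within the scatter) in this assay, so this change gives no step beyond the scatter. The earlier step exchanged the whole aryl group, whereas this one shows that at this place on the ring, the hydroxy, with its hydrogen-bond donor, can give way to cyano, with none, and the number stays within the scatter. No measurement at hand explains this result.

From the compounds shown here alone, whether an amine or a carboxylic acid at this place would give a step beyond the scatter remains open.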